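The source may report more compounds than this note shows. Statements on the series, on what has been measured and on what is new or still open speak of the compounds shown alone.

Compound 2 `CC1=CC[C@@H]([C@@](C)(O)CCCC(C)(C)NC(=S)N/N=C\c2ccc(C)cc2)CC1` carries a 4-methylphenyl group on the shared core. In a functional assay on UACC-62 cells (Homo sapiens) for cytotoxicity, read by sulforhodamine B assay (a higher number here means a weaker inhibitor of growth, a lower number a stronger inhibitor of growth), compound 2 gives 39000 nM. Compound 1 `CC1=CC[C@@H]([C@@](C)(O)CCCC(C)(C)NC(=S)NN)CC1`, which lacks the aryl group, reaches only the limit of > 100000 nM in this assay, (the limit of > 100000 nM in this assay, at which 1 of the 3 values shown sits). Compound 3 `CC1=CC[C@@H]([C@@](C)(O)CCCC(C)(C)NC(=S)N/N=C\c2ccccc2[N+](=O)[O-])CC1` gives 16600 nM in this assay, so compound 2 stands highest of the two plain numbers, with a 2.3-fold lower number from compound 2 to compound 3 (0.37 log units; beyond the scatter) separating it from compound 3. Compound 4 `CC1=CC[C@@H]([C@@](C)(O)CCCC(C)(C)NC(=S)N/N=C\c2ccccc2Cl)CC1` differs from compound 2 by 2-chlorophenyl in place of 4-methylphenyl on a carbon with a double bond to nitrogen. Among the measured compounds shown here, the only measured step that bears on this is the change at the same carbon from compound 2 to compound 3, which gave a 2.3-fold lower number from compound 2 to compound 3 (0.37 log units; beyond the scatter). A step of similar direction and modest size is expected, namely a 2.0-fold lower number from compound 2 to compound 4 (0.29 log units; within the scatter). Compound 4 is therefore estimated at 20000 nM, within a range of 8000 nM to 50000 nM.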

Compound 4, concentration for total growth inhibition: > 100000 nM
Compound 4: only a limit was reported; the forecaster's own chance of this, stated with the estimate: 5%; middle value at least 5.0-fold (0.69 log units) away from the limit.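

Compound 4 shows that an aryl group on this carbon does not by itself give a plain reading in this assay, as its result is only a limit: the limit of > 100000 nM in this assay, at which 2 of the 4 values shown sit.

Placing 2-chlorophenyl for 4-methylphenyl moves the number the opposite way from the nitro change, with an at least 2.5-fold higher number from compound 2 to compound 4 (0.40 log units; beyond the scatter), and chloro in place of nitro on an aromatic carbon gives an at least 6.0-fold higher number from compound 3 to compound 4 (0.77 log units; beyond the scatter). The step from compound 1 to compound 4 joins two limits and cannot be read.

The compounds shown leave open whether this change follows from chloro as such or from where it sits on the ring. As far as these compounds go, how an amine or a carboxylic acid in place of nitro on that aromatic carbon would read also stays open.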